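Shrinking the Amine Ring on the Side Chain of Compound 1

The compounds below may be only part of what the source reports. "The series", "measured", "known", "first", "only" and "open" are said of these compounds alone.

Compound 1 `O=c1cc(-c2ccccc2)oc2cc(OCc3ccccc3)c(OCCCCN3CCCCC3)c(O)c12` is one of two compounds tested in a functional assay on HepG2 cells (Homo sapiens) for antiproliferative activity, read by MTT assay, with a stated time of 48 h; a higher number here means a weaker inhibitor, a lower number a stronger inhibitor. In this assay compound 1 gives 2400 nM, the lowest of the two numbers recorded. Among the compounds with values here, its only companion, compound 2 `COc1cc2oc(-c3ccccc3)cc(=O)c2c(O)c1OCCCCN1CCCCC1`, gives 21000 nM in this assay, and the single measured step, an 8.8-fold higher number from compound 1 to compound 2 (0.94 log units; beyond the scatter), is the only comparison available so far.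

Compound 3 `O=c1cc(-c2ccccc2)oc2cc(OCc3ccccc3)c(OCCCCN3CCCC3)c(O)c12` has not been measured. It differs from compound 1 in one place: pyrrolidin-1-yl in place of piperidin-1-yl on a saturated chain carbon, four bonds along the chain from an oxygen on an aromatic ring. Within the data shown here, no measured pair shows this change. Among the measured compounds shown here, the one step that exists, an 8.8-fold higher number from compound 1 to compound 2 (0.94 log units; beyond the scatter), concerns a different position on the shared core and does not bear on the amine ring, so it offers no guide to what the contraction from a six-membered to a five-membered ring will do.

With nothing in the data to point one way or the other, the author expects compound 3 to sit close to compound 1, with an estimated step of a 1.2-fold higher number from compound 1 to compound 3 (0.07 log units; within the scatter), within the scatter. The estimate for compound 3 in this assay is 2800 nM, expected to fall between 1000 nM and 8000 nM.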

Compound 3, half-maximal inhibitory concentration: 2000 nM
Compound 3: middle estimate off by 1.4-fold (0.15 log units), on the high side, and the stated range covers the measured number.
By their numbers in this assay, from the lowest: compounds 3 and 1 (each within the scatter of the next); then compound 2.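

Within the data shown here, the step, a 1.2-fold lower number from compound 1 to compound 3 (0.08 log units; within the scatter) in this assay, gives the first reading at this position: with pyrrolidin-1-yl in place of piperidin-1-yl on a saturated chain carbon, four bonds along the chain from an oxygen on an aromatic ring, the two numbers cannot be told apart. Within this pair, then, the size of the amine ring makes no difference that the assay can resolve, whereas the one earlier step, an 8.8-fold higher number from compound 1 to compound 2 (0.94 log units; beyond the scatter), at a different position on the shared core, lies beyond the scatter. No supporting evidence is available to account for this result.

A single pair of saturated rings leaves open what other groups would do at the end of the chain, such as azepan-1-yl, morpholin-4-yl or an open-chain amine like diethylamino, and whether a shorter or longer chain would give a different number. It also leaves open whether the same ring change would read alike on compound 2, where the group on the shared core differs, so the present result speaks only for the core of compound 1.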